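The source may hold more compounds than are shown below. What is called first, only, known or untested is meant among the compounds shown, and "the series" means these compounds.

Of the compounds shown here, three have been tested so far in a functional assay on MCF7 cells (Homo sapiens) for antiproliferative activity, read by MTT assay, with a stated time of 72 h; on this read-out higher numbers stand for weaker inhibition and lower numbers for stronger inhibition. Compound 1 `O=C1COc2ccc(-c3cccc(NS(=O)(=O)c4ccc(F)cc4)c3)cc2N1C1CC1` carries a cyclopropyl on the shared core; in this assay compound 1 gives > 40000 nM, which is a limit of the assay rather than a number. Compound 2 `COc1cccc(N2C(=O)COc3ccc(-c4cnc(Cl)c(NS(=O)(=O)c5ccc(F)cc5)c4)cc32)c1` bears a 3-methoxyphenyl on the core; in this assay compound 2 likewise gives only > 40000 nM, again a limit. Compound 3 `Cc1ccc(N2C(=O)COc3ccc(-c4cnc5ccccc5c4)cc32)cc1` gives > 40000 nM in this assay, also a limit. Compound 2 therefore stands with no number of its own: all three values sit at the limit of > 40000 nM in this assay, at which 3 of the 3 values shown sit, and none of them can be placed above or below another.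

Compound 4 `O=C1COc2ccc(-c3cnc(Cl)c(NS(=O)(=O)c4ccc(F)cc4)c3)cc2N1c1ccccc1` has not yet been measured. It differs from compound 2 in a single place: hydrogen in place of methoxy on an aromatic carbon. Cut one bond further out, the same change reads as 3-methoxyphenyl to phenyl.

Among the compounds with values here, no step between two measured compounds exists here, so the size of this step cannot be read from measurements. Given that the change is a small one and that compound 2 sits only at a limit in this assay, the step is expected to be none beyond the scatter, namely a step that the limit leaves unreadable from compound 2 to compound 4. Compound 4 is accordingly estimated at 50000 nM, with an expected range from 15000 nM to 200000 nM, and most likely the assay would again report only a limit.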

Compound 4, half-maximal inhibitory concentration: > 40000 nM
Compound 4: only a limit was reported (the forecaster's own chance of this, stated with the estimate: 80%); the middle value does not contradict the limit.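

In this assay compound 4 gives > 40000 nM, a limit of the assay and not a number. Within the data shown here, compound 2 also has only a limit, so no step between compound 2 and compound 4 can be read. The compounds shown leave open which structural change, if any, would give a measurable value in this assay: the limit of > 40000 nM in this assay, at which 4 of the 4 values shown sit.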